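Taking the Fluoro Group off Compound 2

This account rests on a few compounds, and the source may have more. Where it says the series, first, only, none or still open, it means among the compounds named here.

For the measured compounds named here, in a functional assay on SW480 cells (Homo sapiens) for antiproliferative activity, read by MTT assay, with a stated time of 48 h (a higher number here means a weaker inhibitor, a lower number a stronger inhibitor), compound 2 `CCCCCCC(CCO)n1cnc2c(Cl)nc(F)nc21` gives 12900 nM, the only exact number available so far. Compound 1 `CCCCCC(CCO)n1cnc2c(Cl)ncnc21` gives > 50000 nM, which is a limit of the assay and not a number.

Compound 3 `CCCCCCC(CCO)n1cnc2c(Cl)ncnc21` has not yet been measured. It differs from compound 2 by hydrogen in place of fluoro on an aromatic carbon, between two ring nitrogen atoms. Going by the values given here, no measured step shows what this swap does, so any forecast is loose.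

A moderate move towards weaker inhibition is expected in this assay, probably beyond the usual scatter. That direction rests on compound 1, with no fluoro group on that carbon, and its limit of > 50000 nM. The expected change is a 1.9-fold higher number from compound 2 to compound 3 (0.29 log units; within the scatter). For compound 3, the estimated value is 25000 nM, with an expected range of 10000 nM to 50000 nM.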

Compound 3, half-maximal inhibitory concentration: 16700 nM
For compound 3 the middle estimate is 1.5-fold (0.18 log units) above the measured one; the range from low to high includes it.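

In this assay, swapping the fluoro group for hydrogen gives a 1.3-fold higher number from compound 2 to compound 3 (0.11 log units; within the scatter). At this aromatic carbon, between two ring nitrogen atoms, the fluoro group therefore makes no difference that this assay can separate from the usual scatter. The chain gives the clearer step, an at least 2.9-fold lower number from compound 1 to compound 3 (0.47 log units; beyond the scatter), with methyl in place of hydrogen on a saturated chain carbon, six bonds along the chain from an aromatic nitrogen. That step rests on a limit held by compound 1 and not on a number, so its true size stays unknown: the limit of > 50000 nM in this assay, at which 1 of the 3 values shown sits.

On these data alone, what an amine on the same aromatic carbon would do remains open. So does whether a longer chain would lower the number further.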